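A few compounds are considered here, and "the series" means these few. Any claim that something is new, unique, unknown or untested is made for them only; others in the source may bear on it.

The series shares the core of compound 1 `Nc1ccc(C(=O)/C=C/c2ccco2)cc1`, which in a functional assay on the whole organism (strain albino) for inhibition, with Rattus norvegicus as the target, read by paw edema, with stated times of 30 min and 4 h, at a dose of 100 mg/kg by the oral route (on this read-out lower numbers stand for less inhibition and higher numbers for more inhibition at the one dose given (going by the name of the read-out)), gives 33%. Compound 2 `O=C(CO[N+](=O)[O-])Nc1ccc(C(=O)/C=C/c2ccco2)cc1` gives 40%, and compound 3 `CC(O[N+](=O)[O-])C(=O)Nc1ccc(C(=O)/C=C/c2ccco2)cc1` gives 49%. On the numbers shown, compound 2 is separated from both other compounds only by steps within the scatter: a number 7 percentage points higher from compound 1 to compound 2 (within the scatter) and a number 9 percentage points higher from compound 2 to compound 3 (within the scatter). Compound 4 `C/C(=N/O)c1ccc(OCC(=O)Nc2ccc(C(=O)/C=C/c3ccco3)cc2)cc1` differs from compound 2 by a group of 10 heavy atoms (8 carbon, 1 nitrogen, 1 oxygen; one six-membered aromatic ring of carbon only) in place of a group of 3 heavy atoms (1 nitrogen, 2 oxygen; no ring), on an oxygen on a saturated carbon. Going by the values given here, no measured step changes this oxygen in a comparable way; the two steps that involve compound 2 are small, so no step beyond the scatter is expected in this assay in either direction. Compound 4 is therefore expected to give 44%, with a range from 30% to 58%. The expected step is a number 4 percentage points higher from compound 2 to compound 4 (within the scatter).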

Compound 4, a percentage reported as inhibition, in the whole organism at one dose (the size of the read-out at that dose, not a potency): 48%
Estimate against measurement, compound 4: 4 percentage points below; the measured number falls inside the stated range.
By their numbers in this assay, from the lowest: compounds 1, 2, 4 and 3 (each within the scatter of the next, the first and the last beyond it).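

In this assay the nitro on this oxygen on a saturated carbon gives way to the group of 10 heavy atoms, with its six-membered aromatic ring of carbon only, and a number 8 percentage points higher from compound 2 to compound 4 (within the scatter) is the whole result of the change. This position therefore takes a much larger group, one that holds a ring, without a step beyond the scatter. No measurement bears on why the number stays within the scatter here. Going by these compounds, what a carboxylic acid or an amine on this oxygen would give remains open, as does a longer chain ending in nitro.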